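Carbonyl substituent change from compound 3 to compound 4

This account rests on a few compounds, and the source may have more. Where it says the series, first, only, none or still open, it means among the compounds named here.

In an ADME assay for protein binding, using equilibrium dialysis, at pH 7.4, tested at 2 uM (on this read-out lower numbers stand for a smaller free fraction and higher numbers for a larger free fraction), compound 1 `CC1CC=C(C(=O)N(c2cc(C#CC(C)(C)C)sc2C(=O)O)C(C)C)CC1` gives 0.08, compound 2 `CC(C)N(c1cc(C#CC(C)(C)C)sc1C(=O)O)C(=O)[C@H]1CC[C@H](C)CC1` gives 0.06 and compound 3 `CC(C)N(C(=O)[C@H]1[C@@H]2CCCC[C@@H]21)c1cc(C#CC(C)(C)C)sc1C(=O)O` gives 0.04. Compound 3 is not separated from the other two: a 2.0-fold lower number from compound 1 to compound 3 (0.30 log units; within the scatter) and a 1.5-fold lower number from compound 2 to compound 3 (0.18 log units; within the scatter) both lie within the scatter, as does a 1.3-fold lower number from compound 1 to compound 2 (0.12 log units; within the scatter).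

Compound 4 `CC(C)N(C(=O)[C@H]1CC[C@@H]2C[C@@H]2CC1)c1cc(C#CC(C)(C)C)sc1C(=O)O` differs from compound 3 on the carbonyl carbon: a group of 8 heavy atoms (8 carbon; one three-membered non-aromatic ring of carbon only, one seven-membered non-aromatic ring of carbon only) in place of a group of 7 heavy atoms (7 carbon; one three-membered non-aromatic ring of carbon only, one six-membered non-aromatic ring of carbon only), on a carbonyl carbon. All three measured steps exchange groups at this same place, but none introduces a seven-membered non-aromatic ring of carbon only, so direct precedent is missing. The closest evidence is a 1.5-fold lower number from compound 2 to compound 3 (0.18 log units; within the scatter), and the largest change at this place is a 2.0-fold lower number from compound 1 to compound 3 (0.30 log units; within the scatter), still within the scatter. No step beyond the scatter is therefore expected in this assay. The expected step is a 1.1-fold lower number from compound 3 to compound 4 (0.06 log units; within the scatter), an estimate that stays within the scatter. Compound 4 is estimated at 0.035, with an expected range from 0.018 to 0.07.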

Compound 4, unbound fraction: 0.08
Estimate against measurement, compound 4: 2.3-fold (0.36 log units) below, outside the stated range (above it).
By their numbers in this assay, from the lowest: compounds 3, 2, 1 and 4 (each within the scatter of the next).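

On the carbonyl carbon, the group with a seven-membered and a three-membered non-aromatic carbon ring gives no step beyond the scatter in this assay: a 2.0-fold higher number from compound 3 to compound 4 (0.30 log units; within the scatter), a 1.3-fold higher number from compound 2 to compound 4 (0.12 log units; within the scatter) and no change at the digits printed from compound 1 to compound 4 (within the scatter). This extends the earlier picture to a larger ring at this place, and compounds 1, 2, 3 and 4 remain unseparated by this read-out, although the change adds a heavy atom and a different ring size. No available evidence bears on this result.

Open, on these data alone, is whether a ring carrying a hydroxyl or an amine, or an open alkyl chain, on this carbonyl carbon would give a step beyond the scatter in this assay. Also open, as far as these compounds go, is how a primary amide in place of the carboxylic acid on the shared core would read.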